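The compounds below may be only part of what the source reports. "The series", "measured", "known", "first", "only" and "open" are said of these compounds alone.

Of the compounds shown here, three built on one shared core have been tested in an assay on isolated protein for inhibition of lysosomal alpha-glucosidase (Rattus norvegicus), read by spectrophotometry, with a stated time of 5 min; on this read-out higher numbers stand for weaker inhibition and lower numbers for stronger inhibition. Compound 1 `O=C(/C=C/c1ccc(O)c(O)c1)c1cc2ccoc2cc1O` gives 18900 nM there, compound 2 `O=C(/C=C/c1ccccc1)c1cc2ccoc2cc1O` gives 14500 nM in this assay, and compound 3 `COc1ccc(/C=C/C(=O)c2ccc3occc3c2O)c(OC)c1OC` gives 17300 nM in this assay. The number for compound 3 falls between those of compound 1 and compound 2, and both gaps lie within the usual scatter of repeated measurements, so the three compounds cannot be separated on these data.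

Compound 4 `COc1ccc(/C=C/C(=O)c2ccc3occc3c2O)cc1OC` has not yet been measured in this assay. It differs from compound 3 in one place: hydrogen in place of methoxy on an aromatic carbon. Among the measured compounds shown here, no pair of measured compounds differs by a single change of this kind, so the size of the step cannot be read from a precedent. What the data do show is that compound 2, which carries no group at all on that ring, and compound 3, which carries three methoxy groups, give values within the scatter of each other in this assay, and compound 1 with two hydroxy groups sits in the same band. On that basis the step from compound 3 to compound 4 is expected to be small, a 1.1-fold lower number from compound 3 to compound 4 (0.03 log units; within the scatter), with no direction beyond the scatter. Compound 4 is therefore estimated at 16000 nM in this assay, with a likely range from 7000 nM to 36000 nM.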

Compound 4, half-maximal inhibitory concentration: 5000 nM
Estimate against measurement, compound 4: 3.2-fold (0.51 log units) above; measured number outside the range, below it.
By their numbers in this assay, from the lowest: compound 4; then compounds 2, 3 and 1 (each within the scatter of the next).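

Hydrogen in place of methoxy on an aromatic carbon, ortho to a large group, gives a 3.5-fold lower number from compound 3 to compound 4 (0.54 log units; beyond the scatter) in this assay, the first step among the compounds shown that lies beyond the scatter. The earlier compounds shown here stayed within the scatter of one another and no two of them differed in one place, so they could not show that a single group at one position can matter in this assay. Here the two other methoxy groups stay in place and only the one at this position leaves, so the step belongs to this methoxy alone and not to the substitution of the ring as a whole, although nothing at hand explains why the number falls when it goes.

The compounds shown leave open whether the lower number depends on hydrogen itself at this position, or whether fluorine, an amine or an ethoxy group there would keep it as well. They also leave open whether taking away either of the two remaining methoxy groups would bring a step of similar size, or whether the same change would carry over to a compound with the substitution pattern of the core of compound 1.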